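The compounds below may be only part of what the source reports. "The series", "measured", "known", "first", "only" and "open" are said of these compounds alone.

Compound 1 `O=c1cc(-c2ccccc2)oc2cc(OCCCCNc3nc4ccccc4s3)cc(O)c12` is tested in an ADME assay on MDCK cells (Canis lupus familiaris) for cytotoxicity, read by sulforhodamine B assay, with a stated time of 48 h (on this read-out higher numbers stand for weaker inhibition and lower numbers for stronger inhibition), and gives 348 ug/mL. Two measured analogues change a hydrogen on the same aromatic carbon of the shared core. Compound 2 `Cc1ccc2nc(NCCCCOc3cc(O)c4c(=O)cc(-c5ccccc5)oc4c3)sc2c1` gives 294 ug/mL, and compound 3 `O=c1cc(-c2ccccc2)oc2cc(OCCCCNc3nc4ccc(Cl)cc4s3)cc(O)c12` gives 338 ug/mL; both numbers lie within the scatter of compound 1, so compound 1 cannot be set apart from either of them. The steps are a 1.2-fold lower number from compound 1 to compound 2 (0.07 log units; within the scatter) and a 1.0-fold lower number from compound 1 to compound 3 (0.01 log units; within the scatter), and between the two substituted analogues a 1.1-fold higher number from compound 2 to compound 3 (0.06 log units; within the scatter).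

Compound 4 `O=c1cc(-c2ccccc2)oc2cc(OCCCCNc3nc4ccc(C(F)(F)F)cc4s3)cc(O)c12` is not yet measured. It differs from compound 1 by trifluoromethyl in place of hydrogen on an aromatic carbon. Among the measured compounds shown here, the steps that bear on it are the two that start from compound 1, since each replaces the same hydrogen with a different group, and both stayed within the scatter; the comparison of chloro against methyl did the same. Nothing in these three numbers suggests that a group on this aromatic carbon moves the read-out. The expectation for compound 4 in this assay is therefore no step beyond the scatter, that is a 1.1-fold lower number from compound 1 to compound 4 (0.02 log units; within the scatter). The estimate for compound 4 is 330 ug/mL, with a range from 200 ug/mL to 550 ug/mL.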

Compound 4, half-maximal inhibitory concentration: 278 ug/mL
Compound 4: the middle estimate sits 1.2-fold (0.07 log units) above what was measured; the measured number falls inside the stated range.
By their numbers in this assay, from the lowest: compounds 4, 2, 3 and 1 (each within the scatter of the next).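

Notes on this aromatic carbon: trifluoromethyl, with its 4 heavy atoms, also leaves the read-out in this assay within the scatter of the unsubstituted compound (a 1.3-fold lower number from compound 1 to compound 4 (0.10 log units; within the scatter)). The same holds against the two substituted analogues (a 1.2-fold lower number from compound 3 to compound 4 (0.08 log units; within the scatter)) and (a 1.1-fold lower number from compound 2 to compound 4 (0.02 log units; within the scatter)), so hydrogen, methyl, chloro and trifluoromethyl at this place cannot be told apart, and no order among compounds 1, 2, 3 and 4 can be claimed. No measurement at hand offers an explanation for this flat result.

It remains open whether an amine or a carboxylic acid on this same aromatic carbon would also stay within the scatter, since all four groups shown leave the number unmoved. Going by these compounds, it is equally open whether a change away from this carbon, such as a longer chain in place of the four-carbon link of the shared core, would give any step beyond the scatter in this assay.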